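Cytotoxicity of a benzylurea analogue in this series

The compounds below may be only part of what the source reports. "The series", "measured", "known", "first", "only" and "open" are said of these compounds alone.

Compound 1 `Cc1ccc(-c2c(C)nc(NC(=O)NC3CCCCC3)c(C)c2C(OC(C)(C)C)C(=O)O)cc1C`: 7900 nM
Compound 2 `COc1ccc(Nc2nc(C)c(-c3ccc(C)c(C)c3)c(C(OC(C)(C)C)C(=O)O)c2C)cc1`: 28000 nM
Compound 3 `Cc1ccc(-c2c(C)nc(Nc3nc4ccccc4n3C)c(C)c2C(OC(C)(C)C)C(=O)O)cc1C`: 14000 nM

In an ADME assay on MT4 cells (Homo sapiens) for cytotoxicity, read by MTT assay (on this read-out lower numbers stand for higher toxicity in this test and higher numbers for lower toxicity in this test), compound 3 holds the second highest of the three numbers, with its nearest neighbour compound 1 and its furthest neighbour compound 2, both within the scatter. Compound 4 `Cc1ccc(-c2c(C)nc(NC(=O)NCc3ccccc3)c(C)c2C(OC(C)(C)C)C(=O)O)cc1C` differs from compound 3 by benzylcarbamoyl in place of 1-methyl-1H-benzimidazol-2-yl on a nitrogen on an aromatic ring. Compound 1 likewise carries a carbamoyl group on that nitrogen. The step that bears on this change is a 1.8-fold higher number from compound 1 to compound 3 (0.25 log units; within the scatter); that step stayed within the scatter. The step of a 2.0-fold lower number from compound 2 to compound 3 (0.30 log units; within the scatter) also stayed within the scatter. Compound 4 is therefore expected to show a 1.6-fold lower number from compound 3 to compound 4 (0.19 log units; within the scatter), a slight move toward a lower number. The estimate for compound 4 is 9000 nM, with a range from 4000 nM to 22000 nM.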

Compound 4, half-maximal cytotoxic concentration: 17000 nM
Beside the measured number, compound 4's estimate is 1.9-fold (0.28 log units) below it, and the stated range covers the measured number.
By their numbers in this assay, from the lowest: compounds 1, 3, 4 and 2 (each within the scatter of the next, the first and the last beyond it).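

In this assay, neither a 1.2-fold higher number from compound 3 to compound 4 (0.08 log units; within the scatter) nor a 1.6-fold lower number from compound 2 to compound 4 (0.22 log units; within the scatter) separates the groups on this nitrogen on an aromatic ring, since both steps stay within the scatter. The carbamoyl substituent itself does register: benzyl in place of cyclohexyl on an amide-type nitrogen gives a 2.2-fold higher number from compound 1 to compound 4 (0.33 log units; beyond the scatter), a modest step but beyond the scatter. The compounds shown leave open how an amine or a longer chain on that amide-type nitrogen would read in this assay. No evidence available here accounts for any of these steps.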